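This account rests on a few compounds, and the source may have more. Where it says the series, first, only, none or still open, it means among the compounds named here.

Two measured members of the series share one core and differ only in the acyl group on the amide-type nitrogen. Compound 1 `CCC(=O)N(C)c1ccc2[nH]c(-c3n[nH]c4ccccc34)cc2n1` carries a propionyl group and in a functional assay on HL-60 cells (Homo sapiens) for antiproliferative activity, read by MTT assay, with a stated time of 72 h (on this read-out higher numbers stand for weaker inhibition and lower numbers for stronger inhibition), compound 1 gives 6130 nM. Compound 2 `CN(C(=O)c1ccccc1)c1ccc2[nH]c(-c3n[nH]c4ccccc34)cc2n1` carries a benzoyl group and in this assay compound 2 gives 4850 nM. Going by the values given here, the single step between them, a 1.3-fold lower number from compound 1 to compound 2 (0.10 log units; within the scatter), did not move the number beyond the scatter. Compound 2 thus shows the lower of the two numbers, but the two values stand within the scatter of each other.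

Compound 3 `CN(C(=O)CCc1ccccc1)c1ccc2[nH]c(-c3n[nH]c4ccccc34)cc2n1` is not yet measured. It differs from compound 2 by phenethyl in place of phenyl on a carbonyl carbon. Among the compounds with values here, the only step that bears on this change is the one from compound 1 to compound 2, where exchanging ethyl for phenyl on the carbonyl carbon left the number within the scatter. Lengthening that aryl group by a two-carbon chain is therefore expected to give no step beyond the scatter, a 1.0-fold higher number from compound 2 to compound 3 (0.01 log units; within the scatter). Compound 3 is estimated at 5000 nM, with a range from 2000 nM to 12500 nM.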

Compound 3, half-maximal inhibitory concentration: 4730 nM
Compound 3: the middle estimate sits 1.1-fold (0.02 log units) above what was measured, within the range that was stated.
By their numbers in this assay, from the lowest: compounds 3, 2 and 1 (each within the scatter of the next).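

Phenethyl in place of phenyl on the carbonyl carbon leaves the number in this assay within the scatter (a 1.0-fold lower number from compound 2 to compound 3 (0.01 log units; within the scatter)), and phenyl in place of hydrogen on the saturated chain, two bonds along from that carbonyl carbon, does the same (a 1.3-fold lower number from compound 1 to compound 3 (0.11 log units; within the scatter)). With ethyl, phenyl and phenethyl now compared on this carbonyl carbon, all three numbers lie within the scatter of one another, so none of these changes has moved the read-out at this position. No measured evidence bears on why the number holds steady across these groups.

On these data alone, whether an amine or a carboxylic acid at the end of the chain, or a longer chain, would give a step beyond the scatter remains open. Also open, as far as these compounds go, is whether the same holds with hydrogen in place of the methyl on the amide-type nitrogen.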